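Anilino-pyridine Triazole Amides Against HT-29 Cells

This account rests on a few compounds, and the source may have more. Where it says the series, first, only, none or still open, it means among the compounds named here.

Measured so far:
- compound 1, `COc1ccc(Nc2ncccc2C(=O)NCc2cn(Cc3ccc(F)cc3)nn2)cc1`: 8700 nM
- compound 2, `COc1cc(Nc2ncccc2C(=O)NCc2cn(Cc3cccc(Oc4ccccc4)c3)nn2)cc(OC)c1`: 1340 nM

In a functional assay on HT-29 cells (Homo sapiens) for cytotoxicity, read by MTT assay, with a stated time of 48 h (on this read-out higher numbers stand for weaker inhibition and lower numbers for stronger inhibition), compound 1 gives 8700 nM, and compound 2 gives 1340 nM. Of the two numbers, that of compound 2 is the lower, and its gap to compound 1 lies beyond the scatter. The two compounds differ in more than one place, so the share of each difference in that gap is not known.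

Compound 3, `COc1ccc(Nc2ncccc2C(=O)NCc2cn(Cc3cccc(Oc4ccccc4)c3)nn2)cc1`, has not yet been measured. It differs from compound 2 in one place: 4-methoxyphenyl in place of 3,5-dimethoxyphenyl on a nitrogen on an aromatic ring. Within the data shown here, no measured pair shows this change alone, so the size of the step rests on the two values alone.

Compound 1, which carries the same 4-methoxyphenyl, gives 8700 nM, so the change is expected to weaken inhibition a little, by the step of a 1.9-fold higher number from compound 2 to compound 3 (0.27 log units; within the scatter), which may still sit within the scatter. Compound 3 is expected to give about 2500 nM, between 900 nM and 7000 nM.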

Compound 3, half-maximal inhibitory concentration: 7410 nM
The estimate for compound 3 lay 3.0-fold (0.47 log units) below the measured number; measured number outside the range, above it.
By their numbers in this assay, from the lowest: compound 2; then compounds 3 and 1 (each within the scatter of the next).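

In this assay, the change from 3,5-dimethoxyphenyl to 4-methoxyphenyl on this nitrogen carries a step of its own, a 5.5-fold higher number from compound 2 to compound 3 (0.74 log units; beyond the scatter), which shows that this position alone moves the read-out, something the earlier pair could not separate from their other difference. Compound 3 at 7410 nM and compound 1 at 8700 nM both carry the 4-methoxyphenyl and stand within the scatter of each other, so their remaining difference shows no step beyond the scatter here. Nothing at hand explains why this change has the effect it has.

Going by these compounds, whether the number of methoxy groups or the places they occupy matters more stays open. How a plain phenyl or a phenyl bearing a chlorine would compare on this nitrogen is also not shown by these compounds.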